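The source may report more compounds than this note shows. Statements on the series, on what has been measured and on what is new or still open speak of the compounds shown alone.

Measured in a functional assay on SNB-19 cells (Homo sapiens) for inhibition, read by sulforhodamine B assay, with a stated time of 48 h; a lower number here means a stronger inhibitor of growth, a higher number a weaker inhibitor of growth:
compound 1 `O=C(Cc1csc2nc(-c3ccc(Br)cc3)cn12)N/N=C/c1ccccc1O`: 25100 nM
compound 2 `O=C(Cc1csc2nc(-c3ccc(Br)cc3)cn12)N/N=C/c1ccc(O)cc1`: > 100000 nM (a limit of the assay)
compound 3 `COc1cccc(OC)c1/C=N/NC(=O)Cc1csc2nc(-c3ccc(Br)cc3)cn12`: > 100000 nM (a limit of the assay)

Compound 3 has only a limit and no number, > 100000 nM. Compound 3 thus stands at the limit of > 100000 nM in this assay, at which 2 of the 3 values shown sit.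

The next compound, compound 4 `O=C(Cc1csc2nc(-c3ccc(Br)cc3)cn12)N/N=C/c1ccc(Cl)cc1Cl`, carries 2,4-dichlorophenyl in place of 2,6-dimethoxyphenyl on a carbon with a double bond to nitrogen, (2,4-dichlorophenyl in place of 2,6-dimethoxyphenyl on a carbon with a double bond to nitrogen). The shared core stays as it is.

Two measured steps at this same place bear on the change. One is an at least 3.9-fold higher number from compound 1 to compound 2 (0.60 log units; beyond the scatter), and the other is an at least 3.9-fold higher number from compound 1 to compound 3 (0.60 log units; beyond the scatter). Both are at least modest, and they show that the group at this place can move the result. The third, a step that the two limits leave unreadable from compound 2 to compound 3, adds no size. None of the three involves a 2,4-dichlorophenyl group, so the guide is thin. Only compound 1 reads as a number, at 25100 nM, and this marks the one level reached so far in this assay.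

A modest move towards a lower number is therefore expected, though a second reading at the limit would be quite possible. The expected step is an at least 2.0-fold lower number from compound 3 to compound 4 (0.30 log units; that floor lies within the scatter). Compound 4 is estimated at 50000 nM, with an expected range from 16000 nM to 100000 nM.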

Compound 4, concentration for total growth inhibition: > 100000 nM
Compound 4 was reported as a limit; the forecaster's own chance of this, stated with the estimate: 45%; middle value at least 2.0-fold (0.30 log units) from the limit.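

In this assay compound 4 also gives only a limit of the assay, > 100000 nM. The change to 2,4-dichlorophenyl therefore brings no readable gain over 2,6-dimethoxyphenyl, and the position now shows the same ceiling with a group that has no hydrogen-bond donors or acceptors as with one that has hydrogen-bond acceptors, so the ceiling has become the usual result at this place: the limit of > 100000 nM in this assay, at which 3 of the 4 values shown sit. The only step that can be read is an at least 3.9-fold higher number from compound 1 to compound 4 (0.60 log units; beyond the scatter), which leaves 2-hydroxyphenyl as the one group shown at this place that gives a measured number, while the steps to compound 4 from compound 2 and compound 3 cannot be read, since both ends are limits.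

What the compounds leave open is whether the number for compound 1 depends on the hydroxyl group itself, since no other group shown at this place gives a value that could be compared with it. An amine or a carboxylic acid on the phenyl ring at this place, or a longer chain in place of the ring, could show whether anything else at this position comes off the limit.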